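This account rests on a few compounds, and the source may have more. Where it says the series, first, only, none or still open, it means among the compounds named here.

Working notes on the series, read in a functional assay on HT-29 cells (Homo sapiens) for antiproliferative activity, read by sulforhodamine B assay, with a stated time of 48 h; a lower number here means a stronger inhibitor, a higher number a weaker inhibitor. Compound 1 (`CN1CCN(c2ccc(S(=O)(=O)Oc3cccc(Cl)c3)cc2)C1=O`) gives 2100 nM. Compound 2 (`CN1CCN(c2ccc(S(=O)(=O)Oc3cccc(Br)c3)cc2)C1=O`) gives 1300 nM, level with compound 1, as a 1.6-fold lower number from compound 1 to compound 2 (0.21 log units; within the scatter) shows. Compound 3 (`CN1CCN(c2ccc(S(=O)(=O)Oc3ccc(F)cc3)cc2)C1=O`) gives > 100000 nM, which is a limit and not a number. Against that limit, the steps are large: an at least 47-fold higher number from compound 1 to compound 3 (1.67 log units; beyond the scatter) and an at least 76-fold higher number from compound 2 to compound 3 (1.88 log units; beyond the scatter).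

Compound 4 (`CCCCN1CCN(c2ccc(S(=O)(=O)Oc3cccc(Br)c3)cc2)C1=O`) differs from compound 2 by one change: propyl in place of hydrogen on a saturated chain carbon bound to an amide-type nitrogen in a ring. This is propyl in place of hydrogen on a saturated chain carbon bound to an amide-type nitrogen in a ring, or methyl to butyl when cut one bond further out. Within the data shown here, all measured steps alter the aromatic group on an oxygen, and none touches this chain, so no direct precedent exists. Compound 4 keeps the 3-bromophenyl of compound 2, so the large change in an at least 76-fold higher number from compound 2 to compound 3 (1.88 log units; beyond the scatter) is not expected to recur. No step beyond the scatter is expected in this assay, in either direction, though with wide uncertainty. The expected step is a 1.2-fold higher number from compound 2 to compound 4 (0.06 log units; within the scatter). Compound 4 is estimated at 1500 nM, with an expected range from 300 nM to 8000 nM.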

Compound 4, half-maximal inhibitory concentration: 16000 nM
Compound 4: the middle estimate sits 11-fold (1.03 log units) below what was measured; the whole stated range lies below it.
By their numbers in this assay, from the lowest: compounds 2 and 1 (each within the scatter of the next); then compound 4. At a limit, above all of these: compound 3.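

In this assay, all earlier steps altered the aromatic group on an oxygen; this one shows that the chain on the amide-type nitrogen in a ring also matters, with a 12-fold higher number from compound 2 to compound 4 (1.09 log units; beyond the scatter) on going from methyl to butyl while the 3-bromophenyl stays in place. Butyl is tolerated less well than methyl here, though compound 4 still gives 16000 nM. Nothing shown gives a cause for this step.

As far as these compounds go, with only methyl and butyl at this place, it remains open whether the loss grows steadily with chain length or sets in at one length, which ethyl or propyl would help to settle. Also open, from the compounds shown here alone, is whether a hexyl chain, or a butyl chain ending in an amine or a hydroxyl, would behave as butyl does.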